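The source may hold more compounds than are shown below. What is called first, only, known or untested is meant among the compounds shown, and "the series" means these compounds.

Compound 1 `O=C(O)Cc1sc(C(c2ccc(F)cc2)c2ccc(F)cc2)nc1-c1cc(F)cc(F)c1` gives 340 nM in an in vitro functional assay on HEK285-7 cells for antagonist activity at prostaglandin D2 receptor 2 (Homo sapiens), read by BRET and beta-arrestin recruitment; a lower number here means a stronger inhibitor, a higher number a weaker inhibitor. Compound 3 `O=C(O)Cc1sc(C(c2ccc(F)cc2)c2ccc(F)cc2)nc1-c1ccncc1` gives 40 nM. Compound 2 `O=C(O)Cc1sc(C(c2ccc(F)cc2)c2ccc(F)cc2)nc1-c1ccnc(N2CCC2)c1` reaches only a limit of this assay, > 100000 nM; see (the limit of > 100000 nM in this assay, at which 1 of the 3 values shown sits).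

Compound 3 stands lowest of the two numbers shown; compound 1 lies higher, an 8.5-fold lower number from compound 1 to compound 3 (0.93 log units; beyond the scatter). Compound 4 `Nc1cc(-c2nc(C(c3ccc(F)cc3)c3ccc(F)cc3)sc2CC(=O)O)cc(F)n1` differs from compound 3 by 2-amino-6-fluoropyridin-4-yl in place of pyridin-4-yl on an aromatic carbon.

Going by the values given here, two steps bear on this. Adding groups to the pyridin-4-yl ring has so far been costly: an at least 2500-fold lower number from compound 2 to compound 3 (3.39 log units; beyond the scatter), and an at least 290-fold higher number from compound 1 to compound 2 (2.46 log units; beyond the scatter). The 2-amino-6-fluoropyridin-4-yl group also carries substituents on that ring, though not azetidin-1-yl. A higher number is therefore expected, a 50-fold higher number from compound 3 to compound 4 (1.70 log units; beyond the scatter), with wide uncertainty. Compound 4 is estimated at 2000 nM, range 150 nM to 30000 nM.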

Compound 4, half-maximal inhibitory concentration: 1400 nM
Compound 4: middle estimate off by 1.4-fold (0.15 log units), on the high side; measured number inside the range.
By their numbers in this assay, from the lowest: compound 3; then compound 1; then compound 4. At a limit, above all of these: compound 2.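

Substitution on the pyridin-4-yl ring need not drive the compound to the limit in this assay: 2-amino-6-fluoropyridin-4-yl still costs potency, a 35-fold higher number from compound 3 to compound 4 (1.54 log units; beyond the scatter), yet it stays far from the azetidin-1-yl analogue, an at least 71-fold lower number from compound 2 to compound 4 (1.85 log units; beyond the scatter). That comparison rests on a limit, not a number, for compound 2: the limit of > 100000 nM in this assay, at which 1 of the 4 values shown sits. The substituted ring also gives up the advantage of pyridin-4-yl over 3,5-difluorophenyl, a 4.1-fold higher number from compound 1 to compound 4 (0.61 log units; beyond the scatter).

Going by these compounds, the amino and fluoro groups enter together, so their separate contributions remain open. Also open, on these data alone, is how a lone amine or a methoxy group on that ring would read.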